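Cutting the Alkyl Chain Short: Compound 3 to Compound 4

A few compounds are considered here, and "the series" means these few. Any claim that something is new, unique, unknown or untested is made for them only; others in the source may bear on it.

Measured so far:
compound 1 `CCCOC(=O)Nc1ccc([Se]C#N)cc1`, 46300 nM
compound 2 `CCCCOC(=O)Nc1ccc([Se]C#N)cc1`, 12200 nM
compound 3 `CCCCCCOC(=O)Nc1ccc([Se]C#N)cc1`, 35900 nM

In an ADME assay on BEAS-2B cells (Homo sapiens) for cytotoxicity, read by MTT assay, with a stated time of 72 h (on this read-out higher numbers stand for weaker inhibition of growth and lower numbers for stronger inhibition of growth), compound 3 stands second highest of the three numbers; its value lies within the usual scatter of compound 1, while the remaining step reads a 2.9-fold higher number from compound 2 to compound 3 (0.47 log units; beyond the scatter). Compound 4 `CCOC(=O)Nc1ccc([Se]C#N)cc1` arises from compound 3 by hydrogen in place of butyl on a saturated chain carbon, two bonds along the chain from an oxygen next to a carbonyl group. Among the measured compounds shown here, two measured steps touch this chain: a 1.3-fold lower number from compound 1 to compound 3 (0.11 log units; within the scatter), where propyl is added, and a 3.8-fold lower number from compound 1 to compound 2 (0.58 log units; beyond the scatter), where methyl is added. Neither points one way consistently, so for compound 4 only a small shift is expected, a 1.4-fold higher number from compound 3 to compound 4 (0.14 log units; within the scatter), likely not beyond the scatter. Compound 4 is therefore estimated at 50000 nM, with a range from 18000 nM to 140000 nM.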

Compound 4, concentration for total growth inhibition: 46900 nM
Beside the measured number, compound 4's estimate is 1.1-fold (0.03 log units) above it; the range from low to high includes it.
By their numbers in this assay, from the lowest: compound 2; then compounds 3, 1 and 4 (each within the scatter of the next).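

Cutting hexyl to ethyl changes little in this assay (a 1.3-fold higher number from compound 3 to compound 4 (0.12 log units; within the scatter)), and a shorter cut along the chain stays just as small (a 1.0-fold higher number from compound 1 to compound 4 (0.01 log units; within the scatter)). One intermediate chain alone stands apart (a 3.8-fold higher number from compound 2 to compound 4 (0.58 log units; beyond the scatter)). Growth inhibition therefore does not follow chain length steadily: the shortest and longest chains shown agree, while that intermediate chain gives the strongest inhibition.

No measurement at hand explains why that one chain differs. Still open, from the compounds shown here alone, is whether a chain longer than hexyl, or an amine at the chain end, would shift the number.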